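The compounds below may be only part of what the source reports. "The series", "measured", "known", "first", "only" and "open" are said of these compounds alone.

Compound 1 `Cc1ccc2[nH]c(=O)c(CN(Cc3ccc(C(C)(C)C)cc3)[C@H](CO)c3ccccc3)cc2c1` gives > 10000 nM in a toxicity assay on MDCK cells (Canis lupus familiaris) for cytotoxicity, read by crystal violet staining, with a stated time of 48 h (a higher number here means that more compound is tolerated, a lower number that less compound is tolerated), which is a limit of the assay and not a number.
Compound 2 `CCc1ccc2[nH]c(=O)c(CN(Cc3ccc(C(C)(C)C)cc3)[C@H](CO)c3ccccc3)cc2c1` gives > 10000 nM in this assay, again a limit of the assay.
Compound 3 `Cc1ccc2[nH]c(=O)c(CN(Cc3ccc(C(C)(C)C)cc3)C(C)c3ccc(F)cc3)cc2c1` gives > 33000 nM in this assay, also only a limit.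

From compound 1 to compound 2 the change is methyl in place of hydrogen on a saturated chain carbon bound to an aromatic carbon. Because both values are limits, the step that the two limits leave unreadable from compound 1 to compound 2 cannot be sized; the limit of > 10000 nM in this assay, at which 2 of the 3 values shown sit, is all that the pair shows. The two cores differ as 1-(4-fluorophenyl)ethyl in place of 2-hydroxy-1-phenylethyl on an amine nitrogen, and the step that the two limits leave unreadable from compound 1 to compound 3 is likewise unreadable, since compound 3 sits at the limit of > 33000 nM in this assay, at which 1 of the 3 values shown sits.

Compound 4 `CCc1ccc2[nH]c(=O)c(CN(Cc3ccc(C(C)(C)C)cc3)C(C)c3ccc(F)cc3)cc2c1` has not yet been measured in this assay. It differs from compound 3 by methyl in place of hydrogen on a saturated chain carbon bound to an aromatic carbon, the same change as that from compound 1 to compound 2, at the same place. Given that every value so far is a limit, including the limit of > 10000 nM in this assay, at which 2 of the 3 values shown sit, and (the limit of > 33000 nM in this assay, at which 1 of the 3 values shown sits), the step from compound 3 to compound 4 is expected to be about a step that the limit leaves unreadable from compound 3 to compound 4. Compound 4 is therefore estimated at 40000 nM in this assay, most likely reported again as a limit, with a plausible range from 15000 nM to 100000 nM.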

Compound 4, half-maximal cytotoxic concentration: 2800 nM
The estimate for compound 4 lay 14-fold (1.15 log units) above the measured number, and the stated range ends above it.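

In this assay, methyl in place of hydrogen on a saturated chain carbon bound to an aromatic carbon gives an at least 11-fold lower number from compound 3 to compound 4 (1.07 log units; beyond the scatter), so on the core of compound 3 this change clearly goes with less compound being tolerated. The same change on the core of compound 1 cannot be sized, so the series does not show that the effect carries from one core to the other, as both ends of that pair are only limits: the limit of > 10000 nM in this assay, at which 2 of the 4 values shown sit. With the ethyl group kept, 1-(4-fluorophenyl)ethyl in place of 2-hydroxy-1-phenylethyl on the amine nitrogen gives an at least 3.5-fold lower number from compound 2 to compound 4 (0.55 log units; beyond the scatter), which suggests that the result may depend on the group at that nitrogen, but this rests on a single compound with a number.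

On these data alone, it remains open whether a longer chain, such as propyl, or a methoxy group in the place of the ethyl group would lower the number further. As far as these compounds go, it is also open whether an amine or a carboxylic acid on the 1-(4-fluorophenyl)ethyl group would restore tolerance.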